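Replacing the allyloxy group of compound 3

The source may report more compounds than this note shows. Statements on the series, on what has been measured and on what is new or still open speak of the compounds shown alone.

In a functional assay on the whole organism (strain Sprague-Dawley) for inhibition, with Rattus norvegicus as the target, with a stated time of 10 min (a lower number here means that less compound is needed, a higher number that more compound is needed for the effect), compound 1 `O=C(O)c1cnc(-c2ccccc2)[nH]c1=O` gives 50 mg/kg. With propoxy on an aromatic carbon, compound 2 `CCCOc1ccccc1-c1ncc(C(=O)O)c(=O)[nH]1` gives 0.9 mg/kg, and with allyloxy there, compound 3 `C=CCOc1ccccc1-c1ncc(C(=O)O)c(=O)[nH]1` gives 0.5 mg/kg. The step of a 1.8-fold lower number from compound 2 to compound 3 (0.26 log units; within the scatter) stays within the scatter, so compound 3 shares the low end of these numbers with compound 2.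

Compound 4 `C[S+]([O-])c1ccccc1-c1ncc(C(=O)O)c(=O)[nH]1` keeps the shared core but loses the allyloxy group: a group of 3 heavy atoms (1 carbon, 1 oxygen, 1 sulfur; no ring) in place of a group of 4 heavy atoms (3 carbon, 1 oxygen; no ring), on an aromatic carbon. Among the measured compounds shown here, two measured steps bear on this change. Propoxy in place of hydrogen gave a 56-fold lower number from compound 1 to compound 2 (1.74 log units; beyond the scatter), and allyloxy in place of hydrogen gave a 100-fold lower number from compound 1 to compound 3 (2.00 log units; beyond the scatter). Both are large, so a group on this aromatic carbon can matter greatly. Yet both groups are oxygen-linked chains, and no measured compound carries a group joined through sulfur. Part of the gain may therefore remain, but not all of it is expected to. The estimated change is a 6.0-fold higher number from compound 3 to compound 4 (0.78 log units; beyond the scatter), a moderately higher number. For compound 4 the estimated value is 3 mg/kg, with an expected range from 0.6 mg/kg to 15 mg/kg.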

Compound 4, dose for 50% inhibition: > 5 mg/kg
Compound 4 was reported as a limit (the forecaster's own chance of this, stated with the estimate: 10%); middle value at least 1.6-fold (0.22 log units) away from the limit.
By their numbers in this assay, from the lowest: compounds 3 and 2 (each within the scatter of the next); then compound 1.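

In this assay compound 4 gives > 5 mg/kg, which is a limit and not a number. Set against the two oxygen-linked chains, the group joined through sulfur gives an at least 10-fold higher number from compound 3 to compound 4 (1.00 log units; beyond the scatter) and an at least 5.5-fold higher number from compound 2 to compound 4 (0.74 log units; beyond the scatter), so on this aromatic carbon, ortho to a large group, the low numbers of compounds 2 and 3 do not carry over to this replacement. From the compounds shown here alone, the step from hydrogen, compound 1 to compound 4, cannot be read, so it remains unknown whether the group joined through sulfur keeps any of the gain that propoxy and allyloxy gave.

The compounds shown leave open whether the sulfur link or the rest of the group accounts for the change. A methoxy group or a propylthio chain on the same carbon would help to separate the two.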